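One change on the amine nitrogen of compound 2

The source may report more compounds than this note shows. Statements on the series, on what has been measured and on what is new or still open speak of the compounds shown alone.

Of the compounds shown here, three sharing one core have been tested, and none of them reached a measurable value. Going by the values given here, compound 1 `O=C(NNc1ccccc1F)c1ccc(NS(=O)(=O)c2cnc(O)nc2O)cc1` is the first. In a functional assay on OVCAR-3 cells (Homo sapiens) for antiproliferative activity, read by MTT assay, with a stated time of 24 h (on this read-out lower numbers stand for stronger inhibition and higher numbers for weaker inhibition), compound 1 gives only a limit, > 20000 nM. Compound 2 `Cc1cccc(NNC(=O)c2ccccc2NS(=O)(=O)c2cnc(O)nc2O)c1` carries a 3-methylphenyl group on an amine nitrogen. In this assay compound 2 likewise gives only a limit, > 20000 nM. Compound 3 `Cc1ccccc1C(=O)NNC(=O)c1ccc(NS(=O)(=O)c2cnc(O)nc2O)cc1` is the third. In this assay compound 3 also gives only a limit, > 20000 nM. Because (the limit of > 20000 nM in this assay, at which 3 of the 3 values shown sit), compound 2 cannot be placed above or below the other two; it stands at the limit with them.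

Compound 4 `O=C(NNC(=O)c1ccccc1NS(=O)(=O)c1cnc(O)nc1O)c1cccc(Cl)c1` has not been measured. It differs from compound 2 in one place: (3-chlorophenyl)carbonyl in place of 3-methylphenyl on an amine nitrogen. The closest measured comparison is a step that the two limits leave unreadable from compound 1 to compound 3, and since both of its ends sit at the limit, its size cannot be read. With no readable step to lean on, nothing indicates a shift beyond the usual scatter in either direction. Compound 4 is therefore expected to give 20000 nM, with a range from 8000 nM to 50000 nM. The step of a number no higher from compound 2 to compound 4 (the limit leaves the size open) is estimated to be essentially none, and compound 4 is expected most likely to return only a limit again.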

Compound 4, half-maximal inhibitory concentration: 2080 nM
Compound 4: the middle estimate sits 9.6-fold (0.98 log units) above what was measured; measured number below the stated range.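

This position on the amine nitrogen is not silent: in this assay, placing (3-chlorophenyl)carbonyl where 3-methylphenyl stood gives an at least 9.6-fold lower number from compound 2 to compound 4 (0.98 log units; beyond the scatter), so a change at this one place is enough to produce stronger inhibition. Compound 4 gives 2080 nM, the only actual number among the compounds shown, and it offers a fixed point against which later changes on this nitrogen can be compared. The earlier step from compound 1 to compound 3 cannot be read, and the full size of the new step stays open, because compound 2 and both ends of that earlier step are limits rather than numbers: the limit of > 20000 nM in this assay, at which 3 of the 4 values shown sit.

This single step brings in a carbonyl and also puts chlorine where methyl stood, so the compounds shown cannot tell which of the two matters; (3-methylphenyl)carbonyl or 3-chlorophenyl on the same nitrogen would separate them. As far as these compounds go, it also remains open whether a carboxylic acid, an amine or a longer chain at this place would keep, lower or lose the measurable inhibition seen with compound 4.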